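Chlorines exchanged for fluorines on the aryl ketone

The compounds below may be only part of what the source reports. "The series", "measured", "known", "first", "only" and "open" are said of these compounds alone.

Compound 1 `COc1cc(-c2cc(/C=C/C(=O)c3ccc(Cl)c(Cl)c3)[nH]n2)cc(OC)c1OC` is measured in a functional assay on NCI-H522 cells (Homo sapiens) for inhibition, read by sulforhodamine B assay, with a stated time of 48 h (on this read-out higher numbers stand for weaker inhibition of growth and lower numbers for stronger inhibition of growth), where compound 1 gives 3040 nM. Compound 2 `COc1ccc(-c2cc(/C=C/C(=O)c3cc(OC)c(OC)c(OC)c3)[nH]n2)cc1OC` gives 2680 nM and compound 3 `COc1cc(C(=O)/C=C/c2cc(-c3cc(OC)c(OC)c(OC)c3)n[nH]2)cc(OC)c1OC` gives 1700 nM; both values lie within the scatter of compound 1, so the three compounds cannot be told apart on this read-out. For the measured compounds named here, the only step between measured compounds, a 1.6-fold lower number from compound 2 to compound 3 (0.20 log units; within the scatter), concerns a methoxy group and says nothing about the 3,4-dichlorophenyl. Compound 4 `COc1cc(-c2cc(/C=C/C(=O)c3ccc(F)c(F)c3)[nH]n2)cc(OC)c1OC` differs from compound 1 in one place: 3,4-difluorophenyl in place of 3,4-dichlorophenyl on a carbonyl carbon. Going by the values given here, no measured pair shows such a halogen exchange, so no step beyond the scatter is expected, and the estimated change is a 1.2-fold higher number from compound 1 to compound 4 (0.06 log units; within the scatter). Compound 4 is therefore expected to give 3500 nM, within a range from 1200 nM to 10000 nM.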

Compound 4, concentration for total growth inhibition: 4480 nM
The estimate for compound 4 lay 1.3-fold (0.11 log units) below the measured number; measured number inside the range.
By their numbers in this assay, from the lowest: compounds 3, 2, 1 and 4 (each within the scatter of the next, the first and the last beyond it).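

For the compounds shown here, the exchange of 3,4-dichlorophenyl for 3,4-difluorophenyl on a carbonyl carbon gives a 1.5-fold higher number from compound 1 to compound 4 (0.17 log units; within the scatter) in this assay and is the first direct reading of this position. Within this pair, the two halogen patterns cannot be told apart on growth inhibition. Nothing available accounts for this result. From the compounds shown here alone, whether an aryl ketone carrying an amine or a carboxylic acid instead of the halogens would move the number beyond the scatter remains open. The compounds shown also leave open whether this halogen exchange reads the same way in other cell lines.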